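The source may report more compounds than this note shows. Statements on the series, on what has been measured and on what is new or still open speak of the compounds shown alone.

For the measured compounds named here, compound 3, whose structure is `Cc1ccc(C)c(NC(=O)c2ccc(/N=N\c3c[nH]c4ccccc34)cc2)c1`, gives 544000 nM in a functional assay on HCT-116 cells (Homo sapiens) for inhibition, read by MTT assay, with a stated time of 72 h (a lower number here means a stronger inhibitor, a higher number a weaker inhibitor), the highest of the three numbers measured so far. Compound 1, with structure `Cc1ccc(NC(=O)c2ccc(/N=N\c3c[nH]c4ccccc34)cc2)cc1`, gives 25400 nM, and compound 2, with structure `O=C(Nc1ccccc1[N+](=O)[O-])c1ccc(/N=N\c2c[nH]c3ccccc23)cc1`, gives 208000 nM. The recorded steps are an 8.2-fold higher number from compound 1 to compound 2 (0.91 log units; beyond the scatter), a 21-fold higher number from compound 1 to compound 3 (1.33 log units; beyond the scatter) and a 2.6-fold higher number from compound 2 to compound 3 (0.42 log units; beyond the scatter).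

Compound 4, with structure `O=C(Nc1ccccc1F)c1ccc(/N=N\c2c[nH]c3ccccc23)cc1`, differs from compound 3 by 2-fluorophenyl in place of 2,5-dimethylphenyl on an amide-type nitrogen. The step that bears most directly on this change runs the other way in the measured set: going from the 2-nitrophenyl of compound 2 to the 2,5-dimethylphenyl of compound 3 raised the number modestly, and both shorter single-substituent phenyl groups, in compound 1 and compound 2, sit lower than compound 3. A modest to large fall in the number is therefore expected for compound 4, in this assay, amounting to a 5.4-fold lower number from compound 3 to compound 4 (0.74 log units; beyond the scatter). The estimated value for compound 4 is 100000 nM, with a range from 30000 nM to 400000 nM.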

Compound 4, half-maximal inhibitory concentration: 559000 nM
Beside the measured number, compound 4's estimate is 5.6-fold (0.75 log units) below it; measured number outside the range, above it.
By their numbers in this assay, from the lowest: compound 1; then compound 2; then compounds 3 and 4 (each within the scatter of the next).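

In this assay, exchanging 2,5-dimethylphenyl for 2-fluorophenyl on the amide-type nitrogen gives a 1.0-fold higher number from compound 3 to compound 4 (0.01 log units; within the scatter), so at this position the two groups cannot be told apart, and the step seen earlier between 2-nitrophenyl and 2,5-dimethylphenyl is matched by a group carrying neither nitro nor methyl. Fluoro in place of nitro on an aromatic carbon gives a 2.7-fold higher number from compound 2 to compound 4 (0.43 log units; beyond the scatter), and 2-fluorophenyl in place of 4-methylphenyl gives a 22-fold higher number from compound 1 to compound 4 (1.34 log units; beyond the scatter), which leaves compound 1 clearly lowest of the four, with all three groups named with a 2 substituent above it. Nothing measured here accounts for these differences.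

The compounds shown leave open whether 4-fluorophenyl would return the number towards that of compound 1, at 25400 nM. Going by these compounds, whether an amine or a carboxylic acid on this phenyl ring would do the same also stays open.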